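Series notes: chloro added to compound 2, expected cytotoxicity

The source may hold more compounds than are shown below. What is called first, only, known or untested is meant among the compounds shown, and "the series" means these compounds.

Compound 2 `Clc1ccc(/C=N/Nc2nc3ccccc3s2)cc1` is assessed in a functional assay on MDA-MB-435 cells (Homo sapiens) for cytotoxicity, read by MTT assay, with a stated time of 72 h; on this read-out higher numbers stand for weaker inhibition and lower numbers for stronger inhibition. In this assay compound 2 gives > 17300 nM, which is a limit of the assay and not a number, matching (the limit of > 17300 nM in this assay, at which 1 of the 3 values shown sits). Compound 1 `Oc1ccc(/C=N/Nc2nc3ccccc3s2)cc1O` likewise gives only a limit in this assay, > 17500 nM. Compound 3 `CN(C)c1ccc(/C=N/Nc2nc3ccccc3s2)cc1` gives > 16800 nM in this assay, also a limit. Compound 2 thus stands among values that are all limits, and no ordering among them can be read. Among the measured compounds shown here, the one measured step that touches compound 2 is a step that the two limits leave unreadable from compound 2 to compound 3. Compound 4 `Clc1ccc(/C=N/Nc2nc3ccccc3s2)c(Cl)c1` differs from compound 2 by chloro in place of hydrogen on an aromatic carbon. For the measured compounds named here, no measured step reads on this change, so no step beyond the scatter is expected, and a further limit is the likely outcome. Compound 4 is estimated at 25000 nM in this assay, within 8000 nM to 80000 nM. The step that the limit leaves unreadable from compound 2 to compound 4 is the expected result.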

Compound 4, half-maximal inhibitory concentration: > 15500 nM
Compound 4: only a limit was reported; the forecaster's own chance of this, stated with the estimate: 75%; the middle value does not contradict the limit.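

In this assay, among the compounds shown here, compound 4 gives > 15500 nM, a limit and not a number, so no step from compound 2, itself only a limit, can be read. The compounds shown leave open whether chloro in place of hydrogen on an aromatic carbon changes cytotoxicity at all.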